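This account rests on a few compounds, and the source may have more. Where it says the series, first, only, none or still open, it means among the compounds named here.

Measured compounds:
Compound 1, `CCCC[C@@H](/C=C\[C@@H]1OC(=O)C=C[C@@H]1O)OC(C)=O`: 300 nM
Compound 2, `CCCC[C@H](O)/C=C\[C@@H]1OC(=O)C=C[C@@H]1O`: 6200 nM

In a functional assay on HeLa cells (Homo sapiens) for cytotoxicity, read by sulforhodamine B assay, with a stated time of 48 h (a lower number here means a stronger inhibitor, a higher number a weaker inhibitor), compound 1 has the lowest of the two numbers, the nearest being compound 2 with a 21-fold higher number from compound 1 to compound 2 (1.32 log units; beyond the scatter), where hydrogen replaces acetyl on an oxygen on a saturated carbon. Compound 3, `CCCC[C@H](/C=C\[C@@H]1OC(=O)C=C[C@@H]1O)OC(C)=O`, keeps the acetyl and differs from compound 1 only as follows: the two compounds have the same atoms and bonds and differ only in configuration as drawn: 1 of 4 stereo elements differ; a stereocentre at a saturated chain carbon is drawn S in compound 1 and R in compound 3. Going by the values given here, no measured step concerns a change of configuration, so the single step from compound 1 to compound 2 gives no direct guide; the acetyl group itself stays in place. For compound 3 the expected step is a 2.0-fold higher number from compound 1 to compound 3 (0.30 log units; within the scatter), a small change with wide uncertainty, and the estimated value is 600 nM, ranging from 150 nM to 3000 nM.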

Compound 3, half-maximal inhibitory concentration: 1400 nM
For compound 3 the middle estimate is 2.3-fold (0.37 log units) below the measured one, within the range that was stated.
By their numbers in this assay, from the lowest: compound 1; then compound 3; then compound 2.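

In this assay changing a saturated chain carbon from S to R gives a 4.7-fold higher number from compound 1 to compound 3 (0.67 log units; beyond the scatter) with the acetyl group still in place, so the drawn configuration matters as well as the acetyl group. This step is smaller than a 21-fold higher number from compound 1 to compound 2 (1.32 log units; beyond the scatter) on replacing acetyl with hydrogen. The gap between this pair can be assigned to configuration alone because nothing else separates them: the fact that compounds 1 and 3 differ only in the configuration as drawn. Still open, as far as these compounds go, is whether configuration matters equally once the acetyl group is replaced with hydrogen. Also open, from the compounds shown here alone, is how a benzoyl group or an amine at this position would compare.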